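A Fourth Aryl Group Enters a Flat Series

The compounds below may be only part of what the source reports. "The series", "measured", "known", "first", "only" and "open" are said of these compounds alone.

Compound 1 `Nc1scc(CN2CCN(c3cc(Cl)cc(Cl)c3)CC2)c1C(=O)c1ccc(Cl)cc1` gives 1% in an assay on CHO cells for displacement of a labelled ligand from adenosine receptor A3 (Homo sapiens), read by scintillation counting, with a stated time of 120 min, tested at 10 uM; a lower number here means less inhibition, a higher number more inhibition at the concentration tested (going by the name of the read-out).
Compound 2 `Nc1scc(CN2CCN(c3ccc(Cl)cc3F)CC2)c1C(=O)c1ccc(Cl)cc1` gives 1% in this assay.
Compound 3 `Nc1scc(CN2CCN(c3cccnc3)CC2)c1C(=O)c1ccc(Cl)cc1` gives 0% in this assay.

Compound 3 has the lowest of the three numbers, but its nearest neighbour, compound 1, sits only a number 1 percentage points lower from compound 1 to compound 3 (within the scatter), and compound 2 is no further away, a number 1 percentage points lower from compound 2 to compound 3 (within the scatter); all three values lie within the scatter of one another, so none can be ranked against the others.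

Compound 4 `Nc1scc(CN2CCN(c3c(F)cccc3F)CC2)c1C(=O)c1ccc(Cl)cc1` carries the change (2,6-difluorophenyl in place of pyridin-3-yl on an amine nitrogen in a ring). Each of the measured steps varies the same aryl group on the same ring nitrogen of the shared core: no change at the digits printed from compound 1 to compound 2 (within the scatter), a number 1 percentage points lower from compound 1 to compound 3 (within the scatter) and a number 1 percentage points lower from compound 2 to compound 3 (within the scatter). None of them moves the read-out beyond the scatter, whether the group is a dichlorophenyl, a chlorofluorophenyl or a pyridinyl. On that basis the step to another substituted phenyl is expected to change nothing beyond the scatter in this assay, giving an expected a number 1 percentage points higher from compound 3 to compound 4 (within the scatter). Compound 4 is therefore estimated at 1%, with a range from -8% to 10%.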

Compound 4, a percentage reported as inhibition, at one concentration (the size of the read-out at that concentration, not a potency): 4%
Estimate against measurement, compound 4: 3 percentage points below, and the stated range covers the measured number.
By their numbers in this assay, from the lowest: compounds 3, 1, 2 and 4 (each within the scatter of the next).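

In this assay, 2,6-difluorophenyl on the amine nitrogen in a ring joins the earlier aryl groups without separating from any of them: a number 4 percentage points higher from compound 3 to compound 4 (within the scatter), a number 3 percentage points higher from compound 2 to compound 4 (within the scatter) and a number 3 percentage points higher from compound 1 to compound 4 (within the scatter). The steps among compounds 1, 2 and 3 had already covered a carbon-only ring and a ring with a hetero atom, and compound 4 extends the same flat result to a further fluorine-bearing phenyl, so all four aryl groups at this position remain unranked in this read-out. Nothing in the material shown bears on why this position stays so flat.

Every group shown here is an aromatic ring attached directly to the ring nitrogen, so it remains open whether a benzyl group, an acetyl group or a longer alkyl chain such as n-butyl in that place would move the number beyond the scatter. Because these are readings at a single concentration, they also leave open whether a change elsewhere on the shared core, such as acylating its free amine, would give this aryl position any measurable influence.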